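This account rests on a few compounds, and the source may have more. Where it says the series, first, only, none or still open, it means among the compounds named here.

Compounds measured so far in a functional assay on HeLa cells (Homo sapiens) for cytotoxicity, read by MTT assay, with a stated time of 48 h; a lower number here means a stronger inhibitor, a higher number a weaker inhibitor
compound 1 `CCOC(=O)[C@]1(C(=O)NCc2ccc(C)cc2)C[C@H]1c1cc(OC)c(OC)c(OC)c1` with 28500 nM
compound 2 `CCOC(=O)[C@]1(C(=O)Nc2ccccc2Cl)C[C@@H]1c1cc(OC)c(OC)c(OC)c1` with > 100000 nM
compound 3 `COc1cc([C@H]2C[C@]2(CO)C(=O)NCc2ccc(C)cc2)cc(OC)c1OC` with 57800 nM

Compound 2 gives > 100000 nM as a limit of the assay and not a number. Compound 3 at 57800 nM holds the higher of the two actual numbers, and compound 1 at 28500 nM lies nearest, lower by more than the usual scatter.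

Compound 4 `CCOC(=O)[C@]1(C(=O)NCc2ccc(C)cc2)C[C@@H]1c1cc(OC)c(OC)c(OC)c1` carries ethoxycarbonyl in place of the hydroxymethyl of compound 3 on a saturated ring carbon, a change counted as ethoxycarbonyl in place of hydroxymethyl on a saturated ring carbon here. Among the measured compounds shown here, no measured pair shows this change alone. Compound 1 also bears ethoxycarbonyl and gives 28500 nM in this assay, so a similar or slightly lower number is expected. The expected 1.5-fold lower number from compound 3 to compound 4 (0.18 log units; within the scatter) stays within the scatter. Compound 4 is estimated at 38000 nM with an expected range from 14000 nM to 100000 nM.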

Compound 4, half-maximal inhibitory concentration: > 100000 nM
Compound 4 ended at the assay's limit; the forecaster's own chance of this, stated with the estimate: 20%; at least 2.6-fold (0.42 log units) between middle value and limit.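

In this assay, ethoxycarbonyl in place of hydroxymethyl on this saturated ring carbon gives an at least 1.7-fold higher number from compound 3 to compound 4 (0.23 log units; that floor lies within the scatter), so the size of this change stays unsettled. The clearer finding is an at least 3.5-fold higher number from compound 1 to compound 4 (0.54 log units; beyond the scatter), a gap that can be put down to the drawn configuration alone: the fact that compounds 1 and 4 differ only in the configuration as drawn. The step between compound 2 and compound 4 cannot be read, since both values are limits: the limit of > 100000 nM in this assay, at which 2 of the 4 values shown sit.

On these data alone, how an amine or a carboxylic acid on this ring carbon would read in this assay remains open. So does how hydroxymethyl would read in the other drawn configuration.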